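Trimming the hydrazone aryl group in a quinoxaline series

The source may hold more compounds than are shown below. What is called first, only, known or untested is meant among the compounds shown, and "the series" means these compounds.

Measured so far:
- compound 1, `C/C(=N\Nc1nc2ccccc2nc1Cc1ccccc1)c1cccs1`, 850000 nM
- compound 2, `Cc1ccsc1/C=N/Nc1nc2ccccc2nc1Cc1ccccc1`, 860000 nM

Both compounds were tested in an assay on isolated protein for inhibition of Amine oxidase [flavin-containing] B (Homo sapiens), read by spectrophotometry (a higher number here means a weaker inhibitor, a lower number a stronger inhibitor), and both give very high numbers, meaning only weak inhibition. Compound 2 gives the higher of the two values, but the step of a 1.0-fold higher number from compound 1 to compound 2 (0.01 log units; within the scatter) shows that swapping one thiophene-containing group for another changed nothing beyond the scatter, so the two compounds stand on equal footing.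

Compound 3, `C=NNc1nc2ccccc2nc1Cc1ccccc1`, goes further: a group of 2 heavy atoms (1 carbon, 1 nitrogen; no ring) in place of a group of 8 heavy atoms (6 carbon, 1 nitrogen, 1 sulfur; one five-membered aromatic ring with 1 hetero atom), on a nitrogen on an aromatic ring. The ring that carried the hydrazone is removed altogether, leaving a bare methylene hydrazone. Going by the values given here, no measured step covers this kind of change; the only step available, from compound 1 to compound 2, kept the ring and was flat. With so little to go on, compound 3 is expected to remain a weak inhibitor, and the estimated step of a 1.2-fold higher number from compound 2 to compound 3 (0.07 log units; within the scatter) is small and uncertain. Compound 3 is estimated at 1000000 nM, with a likely range from 300000 nM to 3000000 nM.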

Compound 3, half-maximal inhibitory concentration: 950000 nM
For compound 3 the middle estimate is 1.1-fold (0.02 log units) above the measured one; low and high end bracket the measured number.
By their numbers in this assay, from the lowest: compounds 1, 2 and 3 (each within the scatter of the next).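

In this assay, taking away the five-membered aromatic ring and leaving only the group of 2 heavy atoms gives a 1.1-fold higher number from compound 2 to compound 3 (0.04 log units; within the scatter), and the comparison with the other ring-bearing compound gives a 1.1-fold higher number from compound 1 to compound 3 (0.05 log units; within the scatter). Going by these compounds alone, the earlier pair showed only that one ring-bearing group could stand in for another, whereas these steps show that, at this place on a nitrogen on an aromatic ring, compound 3 cannot be told apart from the compounds that keep the ring, so the ring adds nothing measurable to this weak inhibition. No supporting measurement is available to explain this flat result.

Still open, going by these compounds, is whether any group at this place can give a clearly lower number at all. A longer alkyl chain ending in an amine or a carboxylic acid would be one way to probe that.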